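Swapping a Ring on an Inactive Nucleoside Series

A few compounds are considered here, and "the series" means these few. Any claim that something is new, unique, unknown or untested is made for them only; others in the source may bear on it.

Measured in a functional assay on MCF7 cells (Homo sapiens) for antiproliferative activity, read by sulforhodamine B assay, with a stated time of 72 h (a lower number here means a stronger inhibitor, a higher number a weaker inhibitor), so far:
- Compound 1 `OC[C@H]1O[C@@H](n2cnc3c(N4CCN(C5CCCCC5)CC4)ncnc32)[C@H](O)[C@@H]1O` gives "not active" (no number reported)
- Compound 2 `Cc1ccc(N2CCN(c3ncnc4c3ncn4[C@@H]3O[C@H](CO)[C@@H](O)[C@H]3O)CC2)cc1` gives > 100000 nM (a limit, not a number)
- Compound 3 `Nc1nc(N2CCN(c3ncccn3)CC2)c2ncn([C@@H]3O[C@H](CO)[C@@H](O)[C@H]3O)c2n1` gives "not active" (no number reported)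

Like compound 1, compound 3 is recorded as "not active" (no number reported) and so has no single number. Compound 4 `Nc1nc(N2CCN(c3ccc(F)cc3)CC2)c2ncn([C@@H]3O[C@H](CO)[C@@H](O)[C@H]3O)c2n1` is still unmeasured. The structural change 4-fluorophenyl in place of pyrimidin-2-yl on an amine nitrogen in a ring puts 4-fluorophenyl in place of pyrimidin-2-yl on an amine nitrogen in a ring. Among the compounds with values here, no compound here shows measurable activity, and compound 2 sits at the limit > 100000 nM with a carbon-only aromatic ring in that place. Any step in this assay is therefore expected to be small, towards stronger inhibition. Compound 4 is estimated at 50000 nM with an expected range of 10000 nM to 150000 nM for its half-maximal inhibitory concentration.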

Compound 4, half-maximal inhibitory concentration: "not active" (no number reported)
Compound 4: no number reported; no gap can be computed for the estimate.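

Within the data shown here, compound 3 and compound 4 both carry no number in this assay, so no step between them can be read. The compounds shown leave open whether any change on the shared core gives measurable activity, and the only figure among them is a limit: the limit of > 100000 nM in this assay, at which 1 of the 4 values shown sits.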